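Ring contraction at the thiocarbonyl amine in compound 4

The source may report more compounds than this note shows. Statements on the series, on what has been measured and on what is new or still open speak of the compounds shown alone.

Among the compounds with values here, compound 3 `Cc1cccc(/C(N)=N/NC(=S)N2CCCCC2)n1` gives 36.6% in a functional assay on A-431 cells (Homo sapiens) for cytotoxicity, read by MTT assay, with a stated time of 72 h, tested at 3 uM (a higher number here means more inhibition of growth at the concentration tested, a lower number less inhibition of growth), and stands lowest of the three numbers so far, though only its gap to compound 1 is beyond the scatter. Compound 1 `Cc1cccc(/C(N)=N/NC(=S)N2CCSCC2)n1` gives 51.7% and compound 2 `Cc1cccc(/C(N)=N/NC(=S)N2CCOCC2)n1` gives 45.8%. The step of a number 15.1 percentage points lower from compound 1 to compound 3 (beyond the scatter) is the only one beyond the scatter, while a number 5.9 percentage points lower from compound 1 to compound 2 (within the scatter) and a number 9.2 percentage points lower from compound 2 to compound 3 (within the scatter) stay within it. Compound 4 `Cc1cccc(/C(N)=N/NC(=S)N2CCCC2)n1` differs from compound 3 by pyrrolidin-1-yl in place of piperidin-1-yl on a thiocarbonyl carbon. Within the data shown here, none of the measured steps changes the ring size: all three swap one six-membered ring for another on the thiocarbonyl carbon, and even the largest of them is only modest. The change to compound 4 is therefore not covered by a measured step, and the size of the measured steps suggests at most a small movement. Compound 4 is expected to land near compound 3, with an expected step of a number 1.6 percentage points lower from compound 3 to compound 4 (within the scatter) in this assay, which is not expected to exceed the scatter. The estimate for compound 4 in this assay is 35%, with an expected range from 20% to 50%.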

Compound 4, percent growth inhibition at one concentration: 47.2%
Estimate against measurement, compound 4: 12.2 percentage points below; the range from low to high includes it.
By their numbers in this assay, from the lowest: compounds 3, 2, 4 and 1 (each within the scatter of the next, the first and the last beyond it).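

In this assay, within the data shown here, the step of a number 10.6 percentage points higher from compound 3 to compound 4 (beyond the scatter) is the first measured change of ring size on the thiocarbonyl carbon, and it shows that going from the six-membered piperidin-1-yl to the five-membered pyrrolidin-1-yl, one carbon fewer, can move the number beyond the scatter. The other two new steps, a number 1.4 percentage points higher from compound 2 to compound 4 (within the scatter) and a number 4.5 percentage points lower from compound 1 to compound 4 (within the scatter), both stay within the scatter, so compound 4 cannot be told apart from compound 1 or compound 2, although pyrrolidin-1-yl carries neither the oxygen of morpholin-4-yl nor the sulfur of thiomorpholin-4-yl; at this position, then, neither of those ring atoms is needed for a number in that range, and among the four compounds only piperidin-1-yl stands apart, and only from compound 1 and compound 4. Nothing available explains why removing one ring carbon gives this result.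

The compounds shown leave open how the number responds to a smaller azetidin-1-yl ring or a larger azepan-1-yl ring on the same carbon, which would show whether the ring size itself follows any trend. They also leave open whether a ring is needed at all, a question that an open-chain dimethylamino or diethylamino group, or a piperazin-1-yl ring, would address.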